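Ether substituent and cytotoxicity: from compound 3 to compound 4

The compounds below may be only part of what the source reports. "The series", "measured", "known", "first", "only" and "open" are said of these compounds alone.

The three measured compounds share a core and differ only in the group on an oxygen on an aromatic ring. In an ADME assay on MRC5 cells (Homo sapiens) for cytotoxicity, read by fluorescence and resazurin assay, with a stated time of 3 days (on this read-out lower numbers stand for stronger inhibition and higher numbers for weaker inhibition), compound 1 `Cc1cn(C2CCN(Cc3cccc(OC4CCCCC4)c3)CC2)c(=O)[nH]c1=O` gives 23600 nM. Compound 2 `Cc1cn(C2CCN(Cc3cccc(Oc4ccc(Cl)cc4)c3)CC2)c(=O)[nH]c1=O` gives 25100 nM in this assay, and a 1.1-fold higher number from compound 1 to compound 2 (0.03 log units; within the scatter). Compound 3 `Cc1cn(C2CCN(Cc3cccc(Oc4cccnc4)c3)CC2)c(=O)[nH]c1=O` reaches only the limit of this assay, > 64000 nM, so no number is known for it. Compound 3 thus sits at the limit of > 64000 nM in this assay, at which 1 of the 3 values shown sits, and is the least cytotoxic of the three, since an at least 2.7-fold higher number from compound 1 to compound 3 (0.43 log units; beyond the scatter) and an at least 2.5-fold higher number from compound 2 to compound 3 (0.40 log units; beyond the scatter).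

Compound 4 `COc1cccc(Oc2cccc(CN3CCC(n4cc(C)c(=O)[nH]c4=O)CC3)c2)c1` differs from compound 3 by 3-methoxyphenyl in place of pyridin-3-yl on an oxygen on an aromatic ring. The two steps that bear on this change are those into compound 3, where pyridin-3-yl entered and the number rose beyond the scatter each time; compound 4 removes pyridin-3-yl again in favour of a carbon-only ring, as in compound 2. The step expected in this assay is therefore downward, an at least 2.1-fold lower number from compound 3 to compound 4 (0.32 log units; beyond the scatter), its size uncertain given that compound 3 offers only a limit. Compound 4 is estimated at 30000 nM, with a range from 12000 nM to 70000 nM.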

Compound 4, half-maximal inhibitory concentration: 25300 nM
Estimate against measurement, compound 4: 1.2-fold (0.07 log units) above; measured number inside the range.
By their numbers in this assay, from the lowest: compounds 1, 2 and 4 (each within the scatter of the next). At a limit, above all of these: compound 3.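

In this assay, three different groups on this oxygen now give numbers within the scatter of one another: a 1.0-fold higher number from compound 2 to compound 4 (0.00 log units; within the scatter), and a 1.1-fold higher number from compound 1 to compound 4 (0.03 log units; within the scatter), so 3-methoxyphenyl, 4-chlorophenyl and cyclohexyl cannot be told apart here. The reverse change, an at least 2.5-fold lower number from compound 3 to compound 4 (0.40 log units; beyond the scatter), shows that the rise seen with pyridin-3-yl is lost again when a ring of carbon only takes its place, and among the four compounds pyridin-3-yl alone gives a separate result. Compound 3 stands apart at a limit of the assay: the limit of > 64000 nM in this assay, at which 1 of the 4 values shown sits.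

As far as these compounds go, the true size of the gap to compound 3 remains open, with only a limit in hand. Also open, from the compounds shown here alone, is whether pyridin-4-yl or a pyrimidine ring on this oxygen would reach the same limit.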